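A few compounds are considered here, and "the series" means these few. Any claim that something is new, unique, unknown or untested is made for them only; others in the source may bear on it.

Measured in an ADME assay on BJ cells (Homo sapiens) for cytotoxicity, with a stated time of 72 h; on this read-out higher numbers stand for an effect only at larger amounts of compound and lower numbers for an effect already at smaller amounts:
- Compound 1 `C=C[C@@](C)(/C=C/c1ccc(O)c(/C=C/C(=O)OCC)c1)CCC=C(C)C`: > 36600 nM, a limit
- Compound 2 `C=C[C@@](C)(/C=C/c1ccc(O)c(/C=C/C(=O)OCc2ccccc2)c1)CCC=C(C)C`: > 36600 nM, a limit
- Compound 3 `C=C[C@@](C)(/C=C/c1ccc(O)c(/C=C/C(N)=O)c1)CCC=C(C)C`: > 36600 nM, a limit

Compound 3 gives > 36600 nM, which is a limit and not a number. The three compounds share (the limit of > 36600 nM in this assay, at which 3 of the 3 values shown sit), so the position of compound 3 relative to the other two cannot be read.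

Compound 4 `C=C[C@@](C)(/C=C/c1ccc(O)c(/C=C/C(=O)NCc2ccc(C(F)(F)F)cc2)c1)CCC=C(C)C` carries 4-(trifluoromethyl)benzyl in place of hydrogen on an amide-type nitrogen.

Going by the values given here, no measured step covers this exact change. The closest is a step that the two limits leave unreadable from compound 1 to compound 2, which also brings in a phenyl group. The other two, a step that the two limits leave unreadable from compound 1 to compound 3 and a step that the two limits leave unreadable from compound 2 to compound 3, show the change to the primary amide, and neither gives a size. Among the compounds with values here, no step of known size or direction can therefore be carried over to compound 4. The most likely result in this assay is expected to be another limit, although a measurable value remains possible. The expected change is an at least 1.0-fold lower number from compound 3 to compound 4 (0.00 log units; that floor lies within the scatter). For compound 4 the estimated value is 36000 nM, with an expected range from 12000 nM to 60000 nM.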

Compound 4, half-maximal effective concentration: > 36600 nM
Compound 4 was reported as a limit; the forecaster's own chance of this, stated with the estimate: 65%; at least 1.0-fold (0.00 log units) between middle value and limit.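

In this assay compound 4 gives > 36600 nM, which is a limit, so the change from compound 3 to compound 4 yields no readable step. The compounds shown leave open whether any of these changes shifts the read-out, because they all sit at one value: the limit of > 36600 nM in this assay, at which 4 of the 4 values shown sit.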